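The compounds below may be only part of what the source reports. "The series", "measured", "known", "first", "only" and "open" are said of these compounds alone.

Measured so far:
Compound 1, `O=C(/C=C/c1ccc(N2CCCC2)cc1)c1ccc([N+](=O)[O-])cc1`: 91.1%
Compound 2, `COc1cc(O)ccc1C(=O)/C=C/c1ccc(F)cc1`: 86.1%
Compound 3, `COc1ccc(/C=C/C(=O)c2ccco2)cc1Br`: 92%

All three were tested in an assay on isolated protein for inhibition of DNA topoisomerase 1 (Homo sapiens), tested at 100 uM (on this read-out higher numbers stand for a stronger effect at the one concentration tested and lower numbers for a weaker effect), and compound 3 gives 92%. Its number is the highest of the three, but the gaps to the other two lie within the scatter of repeated measurements: compound 1 sits nearest and compound 2 furthest, yet neither gap is wide enough to set any of the three apart. No two of these compounds differ in only one place, so no single structural step has yet been measured, and nothing is known about how one exchange of a group shifts the number.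

Compound 4, `COc1ccc(/C=C/C(=O)c2cccs2)cc1Br`, supplies such a step. It differs from compound 3 in one place: thiophen-2-yl in place of furan-2-yl on a carbonyl carbon. Going by the values given here, both the leaving and the entering group are five-membered aromatic rings with one hetero atom and one hydrogen-bond acceptor, and no measured pair shows what this exchange does. In this assay the step is expected to be small, in no direction beyond the scatter, with an estimated size of a number 2 percentage points lower from compound 3 to compound 4 (within the scatter). Compound 4 is therefore expected to give about 90%, within a range from 80% to 97%.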

Compound 4, a percentage reported as inhibition, at one concentration (the size of the read-out at that concentration, not a potency): 74.4%
Estimate against measurement, compound 4: 15.6 percentage points above; measured number below the stated range.
By their numbers in this assay, from the lowest: compound 4; then compounds 2, 1 and 3 (each within the scatter of the next).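

In this assay, going by these compounds alone, putting thiophen-2-yl in place of furan-2-yl on a carbonyl carbon gives a number 17.6 percentage points lower from compound 3 to compound 4 (beyond the scatter), the first single exchange in this set and one that clearly exceeds the usual variation between repeats. The two rings have the same count of heavy atoms, and each is a five-membered aromatic ring with one hetero atom and one hydrogen-bond acceptor, so the groups differ in that the oxygen of the furan ring is replaced by the sulfur of the thiophene ring. This position therefore responds to a change that leaves all of those counts untouched, although no measurement available here explains why the number falls.

This single pair leaves open whether the same exchange would lower the number on a different core, such as those of compound 1 or compound 2, where the groups on the carbonyl carbon and the rest of the structure differ. It also leaves open how this assay would respond on the same carbonyl carbon to a six-membered ring such as phenyl or pyridin-2-yl, or to a five-membered ring with two hetero atoms such as thiazol-2-yl.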